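The compounds below may be only part of what the source reports. "The series", "measured", "known", "first", "only" and "open" are said of these compounds alone.

Compound 1, `Cc1ccnc(NC(=O)c2ccccc2C)c1`, gives 2.8 in a physicochemical assay for lipophilicity, read by HPLC, at pH 7.4; on this read-out higher numbers stand for higher lipophilicity and lower numbers for lower lipophilicity.
Compound 2, `Cc1ccccc1C(=O)Nc1ccc(C#N)cn1`, gives 3.9 in this assay.
Compound 3, `Cc1ccccc1C(=O)Nc1cc(C#N)ccn1`, gives 2.8 in this assay.

On these numbers compound 1 stands level with compound 3 at the digits shown, the two together being the lowest of the three; compound 2 is the furthest from it, with a value higher by an amount beyond the scatter. Among the measured compounds shown here, the only measured step between compounds that differ in one place, no change at the digits printed from compound 1 to compound 3 (within the scatter), shows no movement within the scatter.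

Compound 4, `Cc1ccnc(NC(=O)c2cccc(F)c2C)c1`, has not yet been measured. It differs from compound 1 in one place: fluoro in place of hydrogen on an aromatic carbon. For the measured compounds named here, no measured step concerns fluoro entering in place of hydrogen, so nothing measured bears directly on this change; the one step that exists alters a different group and shows no movement. Going by the values given here, with no direct precedent, a step close to the scatter is expected, if anything upward. Compound 4 is therefore expected at 3, with a range from 2.6 to 3.4. That estimate means an expected step of a number 0.20 log units higher from compound 1 to compound 4 (within the scatter).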

Compound 4, distribution coefficient: 3.5
Estimate against measurement, compound 4: 0.50 log units below; measured number above the stated range.
By their numbers in this assay, from the lowest: compounds 1 and 3 (each within the scatter of the next); then compound 4; then compound 2.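

In this assay fluoro in place of hydrogen on an aromatic carbon, ortho to a methyl group, gives a step of a number 0.70 log units higher from compound 1 to compound 4 (beyond the scatter) and so moves the number beyond the scatter. The only earlier step of no change at the digits printed from compound 1 to compound 3 (within the scatter) concerned cyano in place of methyl at another place, which makes this the first single change among the compounds shown to move the number, and the first sign that this aromatic carbon responds to substitution. Nothing measured accounts for the size of this step.

From the compounds shown here alone, whether a chloro or a methoxy group on the same aromatic carbon would move the number as fluoro does remains open, as does the effect of fluoro on another carbon of that ring. Going by these compounds, it is also open whether the same step would appear in compound 3, which carries a nitrile in place of the methyl group of compound 1.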